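Working notes: 4-fluorobenzyl to 4-chlorobenzyl

The source may hold more compounds than are shown below. What is called first, only, known or untested is meant among the compounds shown, and "the series" means these compounds.

compound 1 `COc1ccc(S(=O)(=O)Oc2ccccc2/C=C(\C#N)C(=O)Nc2nnc(-c3cccs3)s2)cc1`: 76%
compound 2 `COc1ccc(S(=O)(=O)Oc2ccccc2/C=C(\C#N)C(=O)Nc2nnc(Cc3ccc(F)cc3)s2)cc1`: 76%

In a functional assay on RS4-11 cells (Homo sapiens) for inhibition, read by CCK-8 assay, with a stated time of 48 h, tested at 20 uM (on this read-out lower numbers stand for less inhibition of growth and higher numbers for more inhibition of growth at the one concentration tested), compound 2 gives 76%, level with compound 1. The next compound is compound 3 `COc1ccc(S(=O)(=O)Oc2ccccc2/C=C(\C#N)C(=O)Nc2nnc(Cc3ccc(Cl)cc3)s2)cc1`, which has chloro in place of fluoro on an aromatic carbon, para to a large group: chloro in place of fluoro on an aromatic carbon. Going by the values given here, only one measured step is available, and it bears on this change only loosely: no change at the digits printed from compound 1 to compound 2 (within the scatter). That step put 4-fluorobenzyl in place of thiophen-2-yl, so it shows a tolerated change at the same site but not an exchange of fluoro for chloro. No such exchange has been measured in this series. No step beyond the scatter is therefore expected in this assay, and no direction is favoured. The expected step is no change at the digits printed from compound 2 to compound 3 (within the scatter). Compound 3 is estimated at 76%, with an expected range of 64% to 86%.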

Compound 3, percent growth inhibition at one concentration: 77%
For compound 3 the middle estimate is 1 percentage points below the measured one, and the stated range covers the measured number.
By their numbers in this assay, from the lowest: compounds 1, 2 and 3 (each within the scatter of the next).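

In this assay, going by these compounds alone, the exchange gives a number 1 percentage points higher from compound 2 to compound 3 (within the scatter) and is the first direct reading of chloro in place of fluoro on this aromatic carbon, para to a large group. Between these two halogens, the read-out does not separate the compounds. The comparison with the thiophen-2-yl group gives a number 1 percentage points higher from compound 1 to compound 3 (within the scatter) so that 4-chlorobenzyl, like 4-fluorobenzyl, is tolerated at the site on the shared core. No supporting data are available to explain this outcome.

Open, going by these compounds, is whether this tolerance extends beyond halogens to a different group on the same aromatic carbon, such as an amine or a carboxylic acid. Also open, on these data alone, is whether a longer chain in place of the benzyl link holds the same level, and whether full concentration-response data would separate these three compounds.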